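The source may report more compounds than this note shows. Statements on the series, on what has been measured and on what is new or still open speak of the compounds shown alone.

Measured in a functional assay on MDA-MB-231 cells (Homo sapiens) for antiproliferative activity, read by MTT assay, with a stated time of 48 h; a higher number here means a weaker inhibitor, a lower number a stronger inhibitor:
Compound 1 `COc1ccc(N(C)c2ccnc(Cl)n2)cc1OCCCBr`: 1280 nM
Compound 2 `COc1ccc(N(C)c2ccnc(Cl)n2)cc1OCCCCBr`: 992 nM
Compound 3 `COc1ccc(N(C)c2ccnc(Cl)n2)cc1OCCCCCBr`: > 10000 nM

These three compounds share one core and differ only in the chain that ends in bromo. The value of compound 3, > 10000 nM, is a limit of the assay and not a number. The measured steps show a 1.3-fold lower number from compound 1 to compound 2 (0.11 log units; within the scatter), which lies within the scatter. Both steps that end at compound 3 lie beyond it: an at least 7.8-fold higher number from compound 1 to compound 3 (0.89 log units; beyond the scatter) and an at least 10-fold higher number from compound 2 to compound 3 (1.00 log units; beyond the scatter).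

The next compound is compound 4 `COc1ccc(N(C)c2ccnc(Cl)n2)cc1OCCCC[Se]C#N`, and its difference from compound 3 is this: a group of 3 heavy atoms (1 carbon, 1 nitrogen, 1 selenium; no ring) in place of a group of 2 heavy atoms (1 carbon, 1 bromine; no ring), on a saturated chain carbon, four bonds along the chain from an oxygen on an aromatic ring. Losing the bromomethyl restores the chain of compound 2, now ending in the new group. Within the data shown here, no measured step shows what this new group does in place of bromo, so the expectation rests on the chain alone. The closest guide is compound 2 at 992 nM, reached from compound 3 by reversing an at least 10-fold higher number from compound 2 to compound 3 (1.00 log units; beyond the scatter). A clearly lower number is therefore expected, of about that size, with wide uncertainty about the new group. The expected change is an at least 14-fold lower number from compound 3 to compound 4 (1.15 log units; beyond the scatter). For compound 4 the estimated value is 700 nM, with an expected range of 120 nM to 4000 nM.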

Compound 4, half-maximal inhibitory concentration: > 10000 nM
Compound 4 gave a limit, no number (the forecaster's own chance of this, stated with the estimate: 8%); middle value at least 14-fold (1.15 log units) from the limit.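

On a saturated chain carbon, four bonds along the chain from an oxygen on an aromatic ring, a bromine still leaves measurable activity, but the new group of carbon, nitrogen and selenium does not, giving an at least 10-fold higher number from compound 2 to compound 4 (1.00 log units; beyond the scatter). The comparison with the bromo compound that has the shorter chain points the same way, with an at least 7.8-fold higher number from compound 1 to compound 4 (0.89 log units; beyond the scatter), so the return to the chain of compound 2 does not by itself carry over the activity of compound 2 when the bromine is replaced by this group. The step between compound 3 and compound 4 cannot be read, since both values are limits of the assay and not numbers: the limit of > 10000 nM in this assay, at which 2 of the 4 values shown sit.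

As far as these compounds go, what remains open is which part of the new group matters, the selenium or the nitrile with its triple bond, and a plain nitrile or a thiocyanate, with sulfur in place of selenium, at this same place would separate the two. Also open, from the compounds shown here alone, is whether the group behaves the same way on a shorter chain, or whether another chain end, such as an amine, could match compound 2.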